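A few compounds are considered here, and "the series" means these few. Any claim that something is new, unique, unknown or untested is made for them only; others in the source may bear on it.

Measured compounds in a functional assay on HCT-15 cells (Homo sapiens) for inhibition, read by sulforhodamine B assay; a higher number here means a weaker inhibitor of growth, a lower number a stronger inhibitor of growth:
- compound 1, `O=C(CCC1=CCCN(CCCCc2ccc(-c3ccccc3)cc2)C1=O)NO`: 4560 nM
- compound 2, `CC(=O)Nc1ccc(CN2CCC=C(CCC(=O)NO)C2=O)cc1`: "not determined" (no result reported)
- compound 3, `O=C(CCC1=CCCN(CCCc2ccc3ccccc3c2)C1=O)NO`: 530 nM

The three share a core carrying a hydroxamic acid side chain; they differ in the group attached to the ring nitrogen. Compound 1 carries a biphenyl on a four-carbon chain and compound 3 a naphthyl on a three-carbon chain; in this assay compound 3 sits well under compound 1. Compound 2 carries a benzyl bearing an acetamido group, and for compound 2 no number exists in this assay, so compound 2 cannot be placed relative to compound 1 or compound 3.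

Compound 4, `COc1ccc(CN2CCC=C(CCC(=O)NO)C2=O)cc1`, is the next member to be measured. Its difference from compound 2: methoxy in place of acetamido on an aromatic carbon. Among the measured compounds shown here, with no number for compound 2, no step from compound 2 to compound 4 can be given, and neither its size nor its direction in this assay can be stated; the expectation for compound 4 rests on compound 1 and compound 3 alone, both of which carry a longer chain and a larger aromatic group than compound 4. Compound 4 is expected to fall nearer compound 1 than compound 3, estimated at 3000 nM, with a range of 800 nM to 12000 nM.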

Compound 4, concentration for 50% growth inhibition: 6890 nM
Estimate against measurement, compound 4: 2.3-fold (0.36 log units) below; the range from low to high includes it.
By their numbers in this assay, from the lowest: compound 3; then compounds 1 and 4 (each within the scatter of the next).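

In this assay, among the compounds shown here, compound 2 has no number, so no step from compound 2 to compound 4 can be read. The compounds shown leave open whether methoxy in place of acetamido changes growth inhibition in this assay and, if so, in which direction. No evidence at hand bears on this result.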